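A few compounds are considered here, and "the series" means these few. Any claim that something is new, unique, unknown or untested is made for them only; others in the source may bear on it.

Compound 1, `COC(=O)C1=C(c2ccc(Cl)c(Cl)c2)CCC1`, and compound 2, `COC(=O)C1=C(c2ccc(C(C)(C)C)cc2)CCC1`, share one core and differ only in the groups on the benzene ring. In an assay on COS-1 cells for displacement of a labelled ligand from sodium-dependent dopamine transporter (Homo sapiens) (on this read-out lower numbers stand for stronger inhibition and higher numbers for weaker inhibition), compound 1 gives 1900 nM, whereas compound 2 gives 302000 nM. Compound 2 thus stands at the highest number of the two, and the gap to compound 1 is well beyond the usual scatter of such measurements. Within the data shown here, no single-point step between these two is counted, as they differ in more than one place.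

The next compound, compound 3, `COC(=O)C1=C(c2ccc(OC(F)(F)F)cc2)CCC1`, has not yet been measured in this assay. It differs from compound 2 by one change: trifluoromethoxy in place of tert-butyl on an aromatic carbon, para to a group of 9 heavy atoms. Given the high number of compound 2 at 302000 nM, a step towards a lower number is expected for compound 3, of the size a 15-fold lower number from compound 2 to compound 3 (1.18 log units; beyond the scatter), beyond the scatter. The estimate for compound 3 is therefore 20000 nM, with a range from 4000 nM to 100000 nM.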

Compound 3, inhibition constant: 2650000 nM
Beside the measured number, compound 3's estimate is 130-fold (2.12 log units) below it; the measured number lies above the stated range.
By their numbers in this assay, from the lowest: compound 1; then compound 2; then compound 3.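

In this assay, among these compounds, the exchange of tert-butyl for trifluoromethoxy on an aromatic carbon gives an 8.8-fold higher number from compound 2 to compound 3 (0.94 log units; beyond the scatter) on the shared core, and this is the first single change at this position that can be read, as compound 1 and compound 2 differ in more than one place. The step runs towards weaker inhibition and lies beyond the usual scatter, so the group at this position still changes the read-out clearly when the rest of the molecule stays the same, and of these two groups tert-butyl goes with the stronger inhibition. Nothing at hand gives a measured reason for the direction or the size of this step.

The compounds shown leave open how an amine, a carboxylic acid or a longer alkyl chain on the same aromatic carbon would read in this assay and whether any of these would lie on the side of compound 2 or of compound 3. Also open, as far as these compounds go, is whether trifluoromethoxy in place of tert-butyl would give a step of the same direction on a core with a different ester, such as an ethyl ester.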